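A few compounds are considered here, and "the series" means these few. Any claim that something is new, unique, unknown or untested is made for them only; others in the source may bear on it.

In an ADME assay on HFF cells (Homo sapiens) for cytotoxicity, with a stated time of 8 days (a lower number here means that less compound is tolerated, a higher number that more compound is tolerated), compound 2 (`CN(C)c1nc(N)nc2c1ncn2/C=C1/CC1(CO)CO`) gives > 300000 nM as a limit and not as a number. Compound 1 (`C=CCOc1nc(N)nc2c1ncn2/C=C1/CC1(CO)CO`) gives > 300000 nM and is also a limit. Going by the values given here, the only measured step is a step that the two limits leave unreadable from compound 1 to compound 2 and it offers no size to carry forward. The series therefore has no numerical value yet, and all that bears on the next change is the limit of > 300000 nM in this assay, at which 2 of the 2 values shown sit, for compound 1 and compound 2 alike.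

Compound 3 (`CCCSc1nc(N)nc2c1ncn2/C=C1/CC1(CO)CO`) follows from compound 2 with propylsulfanyl in place of dimethylamino on an aromatic carbon on the shared core. Propylsulfanyl replaces dimethylamino, so sulfur enters where nitrogen leaves, and the count of hydrogen-bond acceptors stays the same. With no readable step behind it, the expectation is weak: a small move at most, toward less compound tolerated if it can be read at all, with a good chance of another limit. The expected step is an at least 1.5-fold lower number from compound 2 to compound 3 (0.17 log units; that floor lies within the scatter) on this thin basis. For compound 3 the estimate is 200000 nM with an expected range from 60000 nM to 300000 nM as a working figure.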

Compound 3, half-maximal cytotoxic concentration: > 300000 nM
Compound 3 was reported as a limit; the forecaster's own chance of this, stated with the estimate: 55%; middle value at least 1.5-fold (0.17 log units) from the limit.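

Neither the step from compound 2 to compound 3 nor the step from compound 1 to compound 3 can be read in this assay, and all three results remain limits, not numbers: the limit of > 300000 nM in this assay, at which 3 of the 3 values shown sit.

The compounds shown leave open whether compound 1, compound 2 and compound 3 differ at all in this assay, and whether any group at this place on the shared core would give a number instead of a limit.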